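Moving the nitrile on compound 2

The compounds below may be only part of what the source reports. "The series", "measured", "known", "first", "only" and "open" are said of these compounds alone.

Measured in a functional assay on SH-SY5Y cells (Homo sapiens) for antiproliferative activity, read by MTT assay, with a stated time of 72 h; on this read-out higher numbers stand for weaker inhibition and lower numbers for stronger inhibition:
- compound 1 `COc1cc2c(Nc3ccc(C#N)cc3)ncnc2cc1OCCCN(C)C` gives 34900 nM
- compound 2 `CCN1CCN(CCCOc2cc3ncnc(Nc4ccc(C#N)cc4)c3cc2OC)CC1` gives 5440 nM

Compound 2 holds the lower of these two numbers, which makes it the stronger inhibitor of the pair. Compound 3 `CCN1CCN(CCCOc2cc3ncnc(Nc4ccccc4C#N)c3cc2OC)CC1` differs from it in one place: 2-cyanophenyl in place of 4-cyanophenyl on a nitrogen on an aromatic ring. The same atoms are present but joined differently. Among the compounds with values here, the only measured step is a 6.4-fold lower number from compound 1 to compound 2 (0.81 log units; beyond the scatter), and it lies beyond the usual scatter. That step replaced dimethylamino with 4-ethylpiperazin-1-yl on the chain, so it touches a different place and offers no direct guide. It shows only how far the numbers can move among these compounds. Within the data shown here, no measurement yet tests the change from 4-cyanophenyl to 2-cyanophenyl, so the direction is uncertain, and a smaller shift than that one is expected. The expected step is a 1.3-fold higher number from compound 2 to compound 3 (0.11 log units; within the scatter). For compound 3 the estimated value is 7000 nM, with an expected range from 2000 nM to 20000 nM.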

Compound 3, half-maximal inhibitory concentration: 12600 nM
Beside the measured number, compound 3's estimate is 1.8-fold (0.26 log units) below it; the range from low to high includes it.
By their numbers in this assay, from the lowest: compound 2; then compound 3; then compound 1.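

Moving the nitrile is enough to change the result: in this assay, 2-cyanophenyl in place of 4-cyanophenyl on the nitrogen gives a 2.3-fold higher number from compound 2 to compound 3 (0.36 log units; beyond the scatter), although the two groups have the same atoms and the same counts. Within the data shown here, the earlier step changed only the chain, so this is the first sign that the aromatic group on this nitrogen also matters, and here 4-cyanophenyl gives the lower number. Nothing available explains why the numbers differ.

From the compounds shown here alone, only these two placements of the nitrile can be compared, so it remains open how an unsubstituted phenyl, or a carboxylic acid in place of the nitrile, would compare. Going by these compounds, it is also open whether 2-cyanophenyl would raise the number in the same way when paired with the dimethylamino chain of compound 1.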